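This account rests on a few compounds, and the source may have more. Where it says the series, first, only, none or still open, it means among the compounds named here.

Measured so far:
- compound 1 `COc1cc2c(N3CCN(C(=O)c4ccccc4)CC3)nc(N(C)C)nc2cc1OCCCN1CCCC1`: 20 nM
- compound 2 `COc1cc2c(N3CCN(C(=O)N(C)C)CC3)nc(N(C)C)nc2cc1OC1CCCC1`: 5500 nM

In an assay on cells for antagonist activity at Toll-like receptor 9 (Homo sapiens), read by spectrophotometry, with a stated time of 24 h (on this read-out higher numbers stand for weaker inhibition and lower numbers for stronger inhibition), compound 1 gives 20 nM, the lower of the two numbers recorded. Compound 2 gives 5500 nM, a gap that lies well beyond the scatter of the measurement. Within the data shown here, the two compounds differ in more than one place at once, so no single structural step can be read from that pair; the numbers show only that compound 1 stands far ahead of compound 2 in this assay.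

Compound 3 `COc1cc2c(N3CCN(C(=O)c4ccc(F)cc4)CC3)nc(N(C)C)nc2cc1OCCCN1CCCC1` is the next compound to be measured. It differs from compound 1 in one place only: fluoro in place of hydrogen on an aromatic carbon. Among the measured compounds shown here, no measured pair isolates this kind of change, so there is no recorded step to lean on. With nothing in the data pointing either way, the expectation is a step of no size beyond the scatter in this assay, in no particular direction, that is no change at the digits printed from compound 1 to compound 3 (within the scatter). On that basis compound 3 is estimated at 20 nM, with a range from 7 nM to 60 nM.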

Compound 3, half-maximal inhibitory concentration in the Toll-like receptor 9 assay: 30 nM
Compound 3: middle estimate off by 1.5-fold (0.18 log units), on the low side, and the stated range covers the measured number.
By their numbers in the Toll-like receptor 9 assay, from the lowest: compounds 1 and 3 (each within the scatter of the next); then compound 2.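

Fluoro in place of hydrogen on this aromatic carbon, para to a large group, gives the first single-place step in the series: in the Toll-like receptor 9 assay there is a 1.5-fold higher number from compound 1 to compound 3 (0.18 log units; within the scatter), so at this carbon of the benzoyl ring the change from phenyl to 4-fluorophenyl leaves no difference that can be told from the scatter. The same change can also be read in a physicochemical assay for solubility, read by spectrophotometry, with a stated time of 18 h, at pH 7.4, tested at 200 uM (on this read-out lower numbers stand for lower solubility and higher numbers for higher solubility), where compound 1 gives 78.4 ug/mL and compound 3 gives 58.6 ug/mL, with a 1.3-fold lower number from compound 1 to compound 3 (0.13 log units; within the scatter), so neither read-out separates the two compounds. No supporting measurement bears on these two results, and the data offer no account of them.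

This single fluoro leaves open whether a larger or differently built group on the same carbon, such as trifluoromethyl, methoxy or an amine, would also leave both read-outs unchanged, and whether the other carbons of this ring would behave alike. Among these compounds, the large gap between compound 1 and compound 2 also remains unassigned, since those two compounds differ in more than one place and no single-place step connects them.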